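Adding a Hydroxy Group to an Inactive Series

The compounds below may be only part of what the source reports. "The series", "measured", "known", "first", "only" and "open" are said of these compounds alone.

Measured so far in a functional assay on HL-60 cells (Homo sapiens) for inhibition, read by CCK-8 assay, with a stated time of 48 h; on this read-out lower numbers stand for stronger inhibition and higher numbers for weaker inhibition:
compound 1 `O=S(=O)(NCCNC(=S)Nc1cc(C(F)(F)F)cc(C(F)(F)F)c1)c1ccc(-c2ccccc2OCc2cccc(O)c2)s1` gives > 50000 nM, which is a limit of the assay rather than a number;
compound 2 `O=[N+]([O-])c1ccc(NC(=S)NCCNS(=O)(=O)c2ccc(-c3ccccc3OCc3ccccc3)s2)cc1` gives > 50000 nM, also a limit;
compound 3 `O=S(=O)(NCCNC(=S)Nc1cc(C(F)(F)F)cc(C(F)(F)F)c1)c1ccc(-c2ccccc2OCc2ccccc2)s1` gives 2100 nM.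

Compound 1 arises from compound 3 by one change, (hydroxy in place of hydrogen on an aromatic carbon), and this change weakens inhibition: an at least 23-fold higher number from compound 3 to compound 1 (1.37 log units; beyond the scatter). Compound 4 `O=[N+]([O-])c1ccc(NC(=S)NCCNS(=O)(=O)c2ccc(-c3ccccc3OCc3cccc(O)c3)s2)cc1` is not yet measured; it arises from compound 2 by the same change, (hydroxy in place of hydrogen on an aromatic carbon). The difference between the cores of compound 2 and compound 3 is not broken down here. Going by the values given here, compound 2 already sits at the limit, (the limit of > 50000 nM in this assay, at which 2 of the 3 values shown sit), so no counted step from it can be read. For compound 4 the expected step is a step that the limit leaves unreadable from compound 2 to compound 4, resting on the weakening seen in an at least 23-fold higher number from compound 3 to compound 1 (1.37 log units; beyond the scatter). Compound 4 is therefore estimated at 100000 nM, most likely reported only as a limit.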

Compound 4, half-maximal inhibitory concentration: 10800 nM
Compound 4: the middle estimate sits 9.3-fold (0.97 log units) above what was measured, outside the stated range (below it).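

In this assay, adding the hydroxy group gives an at least 4.6-fold lower number from compound 2 to compound 4 (0.66 log units; beyond the scatter), so the change that weakened inhibition on the core of compound 3 strengthens it on the core of compound 2, and the two steps clearly differ: the same change on two cores in this assay, an at least 23-fold higher number (1.37 log units; beyond the scatter) from compound 3 to compound 1 and an at least 4.6-fold lower number (0.66 log units; beyond the scatter) from compound 2 to compound 4, at least 110-fold (2.04 log units) apart, beyond the scatter of two such steps. As far as these compounds go, compound 2 gives > 50000 nM, which is a limit of the assay and not a number, so the full size of this step stays unknown. These two pairs show that the outcome of this change depends on the core, but they do not show why, or what it would do on any further core.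

From the compounds shown here alone, it remains open whether the reversal follows the nitro group of compound 4 or the trifluoromethyl groups of compound 1. Also open, going by these compounds, is whether a methoxy group or an amine in place of the hydroxy would split the two cores in the same way.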